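Thiophene-to-Furan Exchange on a Shared Nucleoside Core

The compounds below may be only part of what the source reports. "The series", "measured", "known", "first", "only" and "open" are said of these compounds alone.

Three compounds built on one sugar-bearing core were tested in a functional assay on HCT-116 cells (Homo sapiens), read by MTT assay, with a stated time of 72 h; on this read-out lower numbers stand for stronger inhibition and higher numbers for weaker inhibition. Compound 1 `Cc1ncnc2c1c(-c1cccs1)cn2[C@@H]1O[C@H](CO)[C@@H](O)[C@H]1O` reaches only the limit of > 20000 nM. Compound 3 `C#Cc1cn([C@@H]2O[C@H](CO)[C@@H](O)[C@H]2O)c2ncnc(N(C)C)c12` gives 180 nM. Compound 2 `CNc1ncnc2c1c(-c1ccsc1)cn2[C@@H]1O[C@H](CO)[C@@H](O)[C@H]1O` likewise reaches only the limit of > 20000 nM. Compound 2 thus stands at the limit of > 20000 nM in this assay, at which 2 of the 3 values shown sit, far from compound 3. Compound 4 `CNc1ncnc2c1c(-c1ccoc1)cn2[C@@H]1O[C@H](CO)[C@@H](O)[C@H]1O` differs from compound 2 in one place: furan-3-yl in place of thiophen-3-yl on an aromatic carbon. Among the measured compounds shown here, no measured pair shows this exchange, so its effect in this assay cannot be read from the numbers. Such a small exchange gives little ground to expect a step beyond the scatter in either direction, so a number no higher from compound 2 to compound 4 (the limit leaves the size open) is estimated as essentially none. Compound 4 is therefore expected to give about 20000 nM, ranging from 6000 nM to 60000 nM.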

Compound 4, half-maximal inhibitory concentration: > 20000 nM
Compound 4 ended at the assay's limit (the forecaster's own chance of this, stated with the estimate: 70%); the middle value sits exactly at the limit.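

In this assay, compound 2 and compound 4 both end at a limit, so no step between them can be read: the limit of > 20000 nM in this assay, at which 3 of the 4 values shown sit.

The compounds shown leave open whether furan-3-yl in place of thiophen-3-yl changes the activity at all.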